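Sulfonyl aryl variation on the shared core

This account rests on a few compounds, and the source may have more. Where it says the series, first, only, none or still open, it means among the compounds named here.

Measured in a functional assay on HCT-116 cells (Homo sapiens) for antiproliferative activity, read by MTT assay, with a stated time of 72 h; on this read-out higher numbers stand for weaker inhibition and lower numbers for stronger inhibition:
compound 1 `CN(c1ccc2[nH]c(-c3n[nH]c4ccccc34)cc2n1)S(=O)(=O)c1ccc(Cl)cc1`: 5980 nM
compound 2 `COc1ccc(S(=O)(=O)N(C)c2ccc3[nH]c(-c4n[nH]c5ccccc45)cc3n2)c(OC)c1`: 21800 nM

Among the compounds with values here, compound 2 holds the highest of the two numbers; its nearest neighbour is compound 1, and the single step between them, a 3.6-fold higher number from compound 1 to compound 2 (0.56 log units; beyond the scatter), lies beyond the scatter. The next compound, compound 3 `CN(c1ccc2[nH]c(-c3n[nH]c4ccccc34)cc2n1)S(=O)(=O)c1ccc(OC(F)(F)F)cc1`, alters the same position: 4-(trifluoromethoxy)phenyl in place of 2,4-dimethoxyphenyl on a sulfonyl sulfur. Within the data shown here, only the step of a 3.6-fold higher number from compound 1 to compound 2 (0.56 log units; beyond the scatter) bears on this change. It shows that moving from the 4-chlorophenyl of compound 1 to the 2,4-dimethoxyphenyl of compound 2 raised the number by a modest amount; compound 3 returns to a single substituent on the phenyl, as in compound 1, so a step of roughly that size in the opposite direction in this assay is expected, which would bring compound 3 back near compound 1. The data hold no direct comparison of trifluoromethoxy against chloro, so the range is kept wide. For compound 3 the expected value is 7000 nM, between 2500 nM and 20000 nM, i.e. an expected step of a 3.1-fold lower number from compound 2 to compound 3 (0.49 log units; beyond the scatter).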

Compound 3, half-maximal inhibitory concentration: 6040 nM
Estimate against measurement, compound 3: 1.2-fold (0.06 log units) above; low and high end bracket the measured number.
By their numbers in this assay, from the lowest: compounds 1 and 3 (each within the scatter of the next); then compound 2.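

In this assay, within the data shown here, the step of a 1.0-fold higher number from compound 1 to compound 3 (0.00 log units; within the scatter) gives the first direct comparison of trifluoromethoxy with chloro on an aromatic carbon, and it does not separate the two groups at this position. The step of a 3.6-fold lower number from compound 2 to compound 3 (0.56 log units; beyond the scatter) is the same size as the step of a 3.6-fold higher number from compound 1 to compound 2 (0.56 log units; beyond the scatter) but runs the other way, so among the three sulfonyl aryl groups only the 2,4-dimethoxyphenyl of compound 2 stands apart, while the 4-chlorophenyl and 4-(trifluoromethoxy)phenyl groups read alike. Nothing shown explains why compound 2 stands apart from compound 1 and compound 3.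

As far as these compounds go, it remains open whether a phenyl bearing one methoxy group would read like compound 2 or like compound 1 and compound 3, which would show whether the gap follows the methoxy groups themselves or their number. Also open is how far the tolerance seen here extends, since an amine or a carboxylic acid on the phenyl, or a longer chain in its place, has no reading among these compounds in this assay and could behave quite differently.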